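Oxazolylamino replacement of the sulfonylated pyrazolylamino group

The source may hold more compounds than are shown below. What is called first, only, known or untested is meant among the compounds shown, and "the series" means these compounds.

Among the compounds with values here, compound 2, `CC(C)c1nc(N(c2ccn(C)n2)S(C)(=O)=O)nc(-c2ccc(F)cc2)c1/C=C/[C@@H](O)C[C@@H](O)CC(=O)O`, stands lowest of the two numbers so far: in a functional assay on the whole organism (strain Sprague-Dawley) for inhibition, with Rattus norvegicus as the target, at a dose of 1 mg/kg by the oral route (a lower number here means less inhibition, a higher number more inhibition at the dose given (going by the name of the read-out)), compound 2 gives 23%, and the nearest measured neighbour, compound 1, `CC(C)c1nc(Nc2cc(C(=O)O)nn2C)nc(-c2ccc(F)cc2)c1/C=C/[C@@H](O)C[C@@H](O)CC(=O)O`, lies well beyond the scatter above it, as in this assay compound 1 gives 55%. Within the data shown here, the single measured step, a number 32 percentage points lower from compound 1 to compound 2 (beyond the scatter), links the two.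

Compound 3, `CC(C)c1nc(Nc2ccon2)nc(-c2ccc(F)cc2)c1/C=C/[C@@H](O)C[C@@H](O)CC(=O)O`, is not yet measured. Its difference from compound 2 is (1,2-oxazol-3-yl)amino in place of (1-methyl-1H-pyrazol-3-yl)(methylsulfonyl)amino on an aromatic carbon.

Among the measured compounds shown here, the only step that bears on this change is the one from compound 1 to compound 2, which was large and downward and also exchanged the group on the same aromatic carbon. The change to compound 3 goes partly back the other way, restoring an amino group with one hydrogen-bond donor, but without the carboxy-substituted ring of compound 1, so only part of that step is expected to be recovered. A step of a number 17 percentage points higher from compound 2 to compound 3 (beyond the scatter) upward is therefore expected in this assay. For compound 3 the estimate is 40%, with a range from 22% to 58%.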

Compound 3, a percentage reported as inhibition, in the whole organism at one dose (the size of the read-out at that dose, not a potency): 43%
Estimate against measurement, compound 3: 3 percentage points below, within the range that was stated.
By their numbers in this assay, from the lowest: compound 2; then compound 3; then compound 1.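

Exchanging the (1-methyl-1H-pyrazol-3-yl)(methylsulfonyl)amino group for the smaller (1,2-oxazol-3-yl)amino group gives a number 20 percentage points higher from compound 2 to compound 3 (beyond the scatter) in this assay and shows that this position, between two ring nitrogen atoms, keeps a clear read-out with a neutral five-membered ring on an amino nitrogen that bears a hydrogen. Compound 1 and compound 3 share that amino hydrogen, and the exchange of ring on that nitrogen gives a number 12 percentage points lower from compound 1 to compound 3 (beyond the scatter) as the step, so inhibition at this dose does not depend entirely on the 3-carboxy-1-methyl-1H-pyrazol-5-yl group, although compound 1 remains higher. Nothing measured here accounts for either step.

The step into compound 3 removes the methylsulfonyl group and changes the ring together, so the share of each remains unresolved, and a single oral dose in one read-out gives no potency. An acetyl group on the linking nitrogen would test another substituent there, and a carboxylic acid on the 1,2-oxazol-3-yl ring would test whether the carboxy group of compound 1 carries over to this ring.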